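Amide aryl swaps and cytotoxicity on a shared core

The source may report more compounds than this note shows. Statements on the series, on what has been measured and on what is new or still open speak of the compounds shown alone.

Compound 1 `Cc1ccc(NC(=O)CS(=O)(=O)c2nccc(Oc3c(C)cc(C#N)cc3C)n2)cc1C` gives 13900 nM in an ADME assay on MT4 cells (Homo sapiens) for cytotoxicity, read by MTT assay, with a stated time of 4 days; on this read-out lower numbers stand for higher toxicity in this test and higher numbers for lower toxicity in this test.
Compound 2 `Cc1cc(C#N)cc(C)c1Oc1ccnc(S(=O)(=O)CC(=O)Nc2ccc(F)cc2)n1` gives 26100 nM in this assay.
Compound 3 `Cc1cc(C#N)cc(C)c1Oc1ccnc(S(=O)(=O)CC(=O)Nc2cc(Cl)cc(Cl)c2)n1` gives 24000 nM in this assay.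

Compound 1 holds the lowest of the three numbers, yet the gaps to its neighbours are small: a 1.7-fold higher number from compound 1 to compound 3 (0.24 log units; within the scatter) and a 1.9-fold higher number from compound 1 to compound 2 (0.27 log units; within the scatter). The third pair behaves the same way, with a 1.1-fold lower number from compound 2 to compound 3 (0.04 log units; within the scatter). All three measured steps are swaps of the aryl group on the amide-type nitrogen, and none of them moves the read-out beyond the usual scatter.

Compound 4 `Cc1cc(C#N)cc(C)c1Oc1ccnc(S(=O)(=O)CC(=O)Nc2ccc(C#N)cc2F)n1` is not yet measured. Relative to compound 1 the change is 4-cyano-2-fluorophenyl in place of 3,4-dimethylphenyl on an amide-type nitrogen. This is again an aryl swap at the same place, so the three measured steps are the ones that bear on it, and each was within the scatter. No step beyond the scatter is therefore expected in this assay, with the number for compound 4 most likely sitting in the band spanned by compounds 1, 2 and 3. The estimate for compound 4 is 20000 nM, with a range from 8000 nM to 50000 nM. This estimate corresponds to an expected 1.4-fold higher number from compound 1 to compound 4 (0.16 log units; within the scatter).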

Compound 4, half-maximal cytotoxic concentration: > 268000 nM
Compound 4 was reported as a limit; the forecaster's own chance of this, stated with the estimate: 15%; middle value at least 13-fold (1.12 log units) away from the limit.
By their numbers in this assay, from the lowest: compounds 1, 3 and 2 (each within the scatter of the next). At a limit, above all of these: compound 4.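

The aryl group on the amide-type nitrogen had looked like a place where swaps leave the read-out in this assay unchanged, but it can carry a large step: the swap to 4-cyano-2-fluorophenyl gives an at least 19-fold higher number from compound 1 to compound 4 (1.28 log units; beyond the scatter), an at least 11-fold higher number from compound 3 to compound 4 (1.04 log units; beyond the scatter) and an at least 10-fold higher number from compound 2 to compound 4 (1.01 log units; beyond the scatter). Compound 4 stands at a limit of the assay, not at a number: the limit of > 268000 nM in this assay, at which 1 of the 4 values shown sits. Fluorine on the aryl group is not enough by itself, as the swap to 4-fluorophenyl gives only a 1.9-fold higher number from compound 1 to compound 2 (0.27 log units; within the scatter), so the large step appears with the group that holds both the nitrile and the fluorine.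

The compounds shown do not separate those two features, and a 4-cyanophenyl or a 2-fluorophenyl group on the same nitrogen would be needed to tell whether the nitrile alone, or only the combination, goes with the step. They also leave open what other groups at this place, such as a 4-aminophenyl or a 4-carboxyphenyl, would do in this assay.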